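Methyl to ethyl on thiophene sulfonylureas in a mouse model

The source may report more compounds than this note shows. Statements on the series, on what has been measured and on what is new or still open speak of the compounds shown alone.

compound 1, `COc1ccc(S(=O)(=O)NC(=O)Nc2ccc(Cl)cc2)s1`: 100%
compound 2, `CCOc1ccc(S(=O)(=O)NC(=O)Nc2ccc(Cl)cc2)s1`: 96%
compound 3, `Cc1ccsc1S(=O)(=O)NC(=O)Nc1ccc(Cl)cc1`: 62%

Of the compounds shown here, three have been measured in a functional assay on the whole organism (6C3HED cells, Mus musculus) for inhibition, at a dose of 300 mg/kg by the oral route; on this read-out lower numbers stand for less inhibition and higher numbers for more inhibition at the one dose given (going by the name of the read-out). Compound 2 differs from compound 1 by methyl in place of hydrogen on a saturated chain carbon bound to an oxygen on an aromatic ring, which gave a number 4 percentage points lower from compound 1 to compound 2 (within the scatter). Compound 3 differs from compound 1 by 3-methylthiophen-2-yl in place of 5-methoxythiophen-2-yl on a sulfonyl sulfur, which gave a number 38 percentage points lower from compound 1 to compound 3 (beyond the scatter), leaving compound 3 with the lowest of the three numbers. Compound 4, `CCc1ccsc1S(=O)(=O)NC(=O)Nc1ccc(Cl)cc1`, is not yet measured; it differs from compound 3 by methyl in place of hydrogen on a saturated chain carbon bound to an aromatic carbon. This is the same kind of change as that from compound 1 to compound 2, but not the same: there the place was a saturated chain carbon bound to an oxygen on an aromatic ring, here it is a saturated chain carbon bound to an aromatic carbon. For compound 4 a step of a number 4 percentage points lower from compound 3 to compound 4 (within the scatter) is expected because the same kind of change gave a number 4 percentage points lower from compound 1 to compound 2 (within the scatter). Compound 4 is therefore estimated at 58%, with a range from 40% to 76%.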

Compound 4, a percentage reported as inhibition, in the whole organism at one dose (the size of the read-out at that dose, not a potency): 25%
Compound 4: middle estimate off by 33 percentage points, on the high side; measured number below the stated range.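

In this assay, the step from methyl to ethyl did not carry over from one core to the other: the same change on two cores in this assay, a number 4 percentage points lower (within the scatter) from compound 1 to compound 2 and a number 37 percentage points lower (beyond the scatter) from compound 3 to compound 4, 33 percentage points apart, beyond the scatter of two such steps

On the core of compound 3, the change gave a number 37 percentage points lower from compound 3 to compound 4 (beyond the scatter), while 3-ethylthiophen-2-yl in place of 5-methoxythiophen-2-yl gave a number 75 percentage points lower from compound 1 to compound 4 (beyond the scatter). This shows that one step cannot be transferred unchanged between these two cores, but it does not show why, and with the added methyl at different places in the two pairs, the effects of core and place cannot be separated.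

As far as these compounds go, it remains open what a longer chain, such as propyl, would give in place of the ethyl of compound 4. The same question stands for an amine at that place.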